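A few compounds are considered here, and "the series" means these few. Any claim that something is new, unique, unknown or untested is made for them only; others in the source may bear on it.

Measured so far in a functional assay on A-431 cells (Homo sapiens) for inhibition, read by MTT assay, with a stated time of 72 h; a higher number here means a weaker inhibitor, a lower number a stronger inhibitor:
compound 1 `C/C=C/C(=O)Nc1cccc(Oc2nc(Nc3cccc(OC)c3)nc3ccsc23)c1` gives 13100 nM
compound 2 `COc1cccc(Nc2nc(Oc3cccc(NC(=O)C=C(C)C)c3)c3sccc3n2)c1` gives 25800 nM
compound 3 `C/C=C/C(=O)Nc1cccc(Oc2nc(Nc3cccc(C#N)c3)nc3ccsc23)c1` gives 20100 nM

All three sit in the weak range of this assay, and no two of them are separated by more than the scatter. The change from compound 1 to compound 2 is 2-methylprop-1-en-1-yl in place of prop-1-en-1-yl on a carbonyl carbon; it gave a 2.0-fold higher number from compound 1 to compound 2 (0.29 log units; within the scatter). The change from compound 1 to compound 3 is cyano in place of methoxy on an aromatic carbon; it gave a 1.5-fold higher number from compound 1 to compound 3 (0.19 log units; within the scatter). Compound 2 and compound 3 show values close to each other.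

Compound 4 `CC(C)=CC(=O)Nc1cccc(Oc2nc(Nc3cccc(C#N)c3)nc3ccsc23)c1` has not been measured in this assay. Going by the values given here, it differs from compound 3 by 2-methylprop-1-en-1-yl in place of prop-1-en-1-yl on a carbonyl carbon, which is the same change as the one from compound 1 to compound 2, made this time on the core of compound 3 rather than the core of compound 1; the two cores differ by cyano in place of methoxy on an aromatic carbon. Because the earlier instance of this change gave a 2.0-fold higher number from compound 1 to compound 2 (0.29 log units; within the scatter), a step of similar size is expected from compound 3 to compound 4, namely a 2.0-fold higher number from compound 3 to compound 4 (0.30 log units; within the scatter). This rests on a single prior example, so the range is kept wide. Compound 4 is therefore estimated at 40000 nM, expected to fall between 20000 nM and 85000 nM.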

Compound 4, half-maximal inhibitory concentration: 28300 nM
Compound 4: middle estimate off by 1.4-fold (0.15 log units), on the high side, and the stated range covers the measured number.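

In this assay, 2-methylprop-1-en-1-yl in place of prop-1-en-1-yl on a carbonyl carbon gives a 1.4-fold higher number from compound 3 to compound 4 (0.15 log units; within the scatter), and the two instances of this change agree: the same change on two cores in this assay, a 2.0-fold higher number (0.29 log units; within the scatter) from compound 1 to compound 2 and a 1.4-fold higher number (0.15 log units; within the scatter) from compound 3 to compound 4, 1.4-fold (0.15 log units) apart, within the scatter of two such steps. Cyano in place of methoxy on an aromatic carbon gives a 1.1-fold higher number from compound 2 to compound 4 (0.04 log units; within the scatter), and this change also reads alike on both cores: the same change on two cores in this assay, a 1.5-fold higher number (0.19 log units; within the scatter) from compound 1 to compound 3 and a 1.1-fold higher number (0.04 log units; within the scatter) from compound 2 to compound 4, 1.4-fold (0.15 log units) apart, within the scatter of two such steps. Going by these compounds alone, the four compounds therefore form a consistent square, but every step in it lies within the scatter, so this shows only that neither change can be told from the scatter on either core, not that either change has a real effect that transfers from one core to another.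

As far as these compounds go, whether a step beyond the scatter would carry over in the same way remains open, since all four compounds stay in the weak range of this assay. Also open, from the compounds shown here alone, is how a plain ethenyl group, or a chain ending in an amine, would read on the carbonyl carbon of these cores.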